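This account rests on a few compounds, and the source may have more. Where it says the series, first, only, none or still open, it means among the compounds named here.

In an ADME assay on HCT-116 cells (Homo sapiens) for cytotoxicity, read by CellTiter-Glo, with a stated time of 72 h (on this read-out higher numbers stand for weaker inhibition and lower numbers for stronger inhibition), compound 1 `Cc1ccc(-c2ccccc2S(=O)(=O)N2CCC(N3CCC(C)CC3)CC2)cc1` gives > 5000 nM, which is a limit of the assay and not a number. Compound 2 `Cc1cc(C)c(S(=O)(=O)N2CCC(N3CCC(C(C)C)CC3)CC2)c(C)c1` gives > 5000 nM, and this too is a limit. For the measured compounds named here, compound 1 therefore stands with compound 2 at the limit of > 5000 nM in this assay, at which 2 of the 2 values shown sit, and no step between two measured compounds can be read from these data.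

Compound 3 `CC1CCN(C2CCN(S(=O)(=O)c3ccccc3-c3ccc(Cl)cc3)CC2)CC1` keeps the core of compound 1 and alters a single substituent: chloro in place of methyl on an aromatic carbon. This places chloro in place of methyl on an aromatic carbon, para to a large group, so that 4-methylphenyl becomes 4-chlorophenyl.

Going by the values given here, the only close guide is compound 1, at > 5000 nM, again a limit. In this assay, no change beyond the usual scatter is expected from this exchange in either direction, and compound 3 may well be reported only as a limit too. The expected step that the limit leaves unreadable from compound 1 to compound 3 lies within the scatter. For compound 3 the estimated value is 6000 nM, with an expected range from 2500 nM to 15000 nM.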

Compound 3, half-maximal inhibitory concentration: > 5000 nM
Compound 3: no number, only a limit; the forecaster's own chance of this, stated with the estimate: 75%; the middle value lies beyond the limit too.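

Compound 3, like compound 1, is reported only as a limit in this assay, so no step from compound 1 to compound 3 can be read: the limit of > 5000 nM in this assay, at which 3 of the 3 values shown sit.

The compounds shown leave open whether chloro in place of methyl changes the read-out at all, and which change to these compounds, if any, would give a measured number in this assay.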